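Sulfonyl Aryl Swap Toward a Chlorothiazole Sulfonamide

The source may report more compounds than this note shows. Statements on the series, on what has been measured and on what is new or still open speak of the compounds shown alone.

Compound 1 `CC1CCN(C2CCN(S(=O)(=O)c3cccnc3)CC2)CC1` — 2400 nM in a functional assay on DLD-1 cells (Homo sapiens) for antiproliferative activity, read by CellTiter-Glo, with a stated time of 72 h; on this read-out higher numbers stand for weaker inhibition and lower numbers for stronger inhibition
Compound 2 `CC1CCN(C2CCN(S(=O)(=O)c3nccn3C)CC2)CC1` — > 5000 nM, a limit of this assay
Compound 3 `CC1CCN(C2CCN(S(=O)(=O)c3ccc(Br)c(Cl)c3)CC2)CC1` — 12 nM

Compound 3 holds the lowest number in this assay; its nearest neighbour stands a 200-fold lower number from compound 1 to compound 3 (2.30 log units; beyond the scatter). Compound 4 `Cc1nc(Cl)sc1S(=O)(=O)N1CCC(N2CCC(C)CC2)CC1` differs from compound 3 by 2-chloro-4-methyl-1,3-thiazol-5-yl in place of 4-bromo-3-chlorophenyl on a sulfonyl sulfur. For the measured compounds named here, two measured steps bear on this: exchanging a heteroaryl for the dihalophenyl gave a 200-fold lower number from compound 1 to compound 3 (2.30 log units; beyond the scatter) and an at least 410-fold lower number from compound 2 to compound 3 (2.61 log units; beyond the scatter), both large gains, so the reverse move toward a heteroaryl is expected to cost. The entering thiazole carries a chlorine and a methyl, unlike the earlier heteroaryls, so the loss is expected to be smaller than those steps, estimated as a 17-fold higher number from compound 3 to compound 4 (1.22 log units; beyond the scatter). Compound 4 is therefore expected to give 200 nM, between 30 nM and 1500 nM.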

Compound 4, half-maximal inhibitory concentration: 1.6 nM
Compound 4: the middle estimate sits 130-fold (2.10 log units) above what was measured; measured number outside the range, below it.
By their numbers in this assay, from the lowest: compound 4; then compound 3; then compound 1. At a limit, above all of these: compound 2.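

At this position on the sulfonyl sulfur, a heteroaryl is not in itself a loss: 2-chloro-4-methyl-1,3-thiazol-5-yl in place of 4-bromo-3-chlorophenyl gave a 7.5-fold lower number from compound 3 to compound 4 (0.88 log units; beyond the scatter), whereas the earlier heteroaryls stood far behind the dihalophenyl. The heteroaryls themselves differ widely, with a 1500-fold lower number from compound 1 to compound 4 (3.18 log units; beyond the scatter). The step of an at least 3100-fold lower number from compound 2 to compound 4 (3.49 log units; beyond the scatter) starts from a limit of the assay: the limit of > 5000 nM in this assay, at which 1 of the 4 values shown sits.

The compounds shown leave open whether the chlorine or the methyl on the thiazole carries the gain. They also leave open how an amine in place of that chlorine would read in this assay.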